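Amide side-chain variation in the shared core series

A few compounds are considered here, and "the series" means these few. Any claim that something is new, unique, unknown or untested is made for them only; others in the source may bear on it.

Measured so far:
compound 1 `Oc1ccc(-c2nc3cc(C(F)(F)F)ccc3[nH]2)cc1`: in an ADME assay on Vero cells (Chlorocebus sabaeus) for cytotoxicity (on this read-out lower numbers stand for higher toxicity in this test and higher numbers for lower toxicity in this test), compound 1 gives a limit of > 100000 nM.
compound 2 `O=[N+]([O-])c1ccc(-c2nc3cc(C(F)(F)F)ccc3[nH]2)cc1`: in this assay compound 2 gives 45000 nM.
compound 3 `CCN(CC)CC(=O)Nc1ccc(-c2nc3cc(C(F)(F)F)ccc3[nH]2)cc1`: in this assay compound 3 gives 24000 nM.

The value of compound 1 is a limit of the test and not a number (the limit of > 100000 nM in this assay, at which 1 of the 3 values shown sits). Compound 3 is separated from compound 1 by an at least 4.1-fold lower number from compound 1 to compound 3 (0.61 log units; beyond the scatter), and from compound 2 by a 1.9-fold lower number from compound 2 to compound 3 (0.27 log units; within the scatter), so compound 2 and compound 3 sit within the usual scatter of each other. Compound 4 `O=C(CN1CCCCC1)Nc1ccc(-c2nc3cc(C(F)(F)F)ccc3[nH]2)cc1` differs from compound 3 only in the side chain: piperidin-1-yl in place of diethylamino on a saturated chain carbon bound to a carbonyl carbon. Among the compounds with values here, no measured step touches this part of the molecule; the steps of an at least 4.1-fold lower number from compound 1 to compound 3 (0.61 log units; beyond the scatter) and a 1.9-fold lower number from compound 2 to compound 3 (0.27 log units; within the scatter) bring the whole ((diethylamino)methyl)carbonyl)amino group in against hydroxy or nitro, and none trades one amine for another. The shift in this assay is therefore expected to stay within the scatter, a 1.1-fold lower number from compound 3 to compound 4 (0.04 log units; within the scatter). Compound 4 is estimated at 22000 nM, between 9000 nM and 55000 nM.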

Compound 4, half-maximal cytotoxic concentration: 31000 nM
The estimate for compound 4 lay 1.4-fold (0.15 log units) below the measured number; the range from low to high includes it.
By their numbers in this assay, from the lowest: compounds 3, 4 and 2 (each within the scatter of the next). At a limit, above all of these: compound 1.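

In this assay, within the data shown here, piperidin-1-yl in place of diethylamino on a saturated chain carbon bound to a carbonyl carbon gives a 1.3-fold higher number from compound 3 to compound 4 (0.11 log units; within the scatter), the first exchange of one amine for another at this position. Replacing the open diethylamino group with a six-membered ring therefore does not separate the two compounds in this test. Nothing shown accounts for this result.

Open, on these data alone, is whether morpholin-4-yl, a primary amine or a carboxylic acid in place of these amines would give a step beyond the scatter. As far as these compounds go, a longer chain between the carbonyl and the amine also remains open.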